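The source may hold more compounds than are shown below. What is called first, only, known or untested is meant among the compounds shown, and "the series" means these compounds.

Compound 2 `Fc1ccc(C2(c3ccc(F)cc3)CNC(c3cccc(Br)c3)=N2)cc1` gives 4.8 nM in an assay on LM cells for displacement of a labelled ligand from Neuropeptide Y receptor type 5 (Homo sapiens) (a higher number here means a weaker inhibitor, a lower number a stronger inhibitor), the lowest of the two numbers at hand, with compound 1 `Fc1ccc(C2(c3ccc(F)cc3)CNC(c3cccc(C(F)(F)F)c3)=N2)cc1` nearest at 6.2 nM. Between these two there was a 1.3-fold lower number from compound 1 to compound 2 (0.11 log units; within the scatter), a change of bromo for trifluoromethyl that stayed within the scatter. Compound 3 `N#Cc1cccc(C2=NC(c3ccc(F)cc3)(c3ccc(F)cc3)CN2)c1` differs from compound 2 by cyano in place of bromo on an aromatic carbon. That measured step is the only one at this place, and it bears on compound 3 only loosely, since no cyano group has been measured here; the writer therefore expects at most a modest move in this assay, without a clear direction. The estimate for compound 3 in this assay is 8 nM, within 3 nM to 25 nM, meaning a 1.7-fold higher number from compound 2 to compound 3 (0.22 log units; within the scatter).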

Compound 3, half-maximal inhibitory concentration: 2.7 nM
The estimate for compound 3 lay 3.0-fold (0.47 log units) above the measured number; the whole stated range lies above it.
By their numbers in this assay, from the lowest: compounds 3, 2 and 1 (each within the scatter of the next, the first and the last beyond it).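

In this assay, cyano on this aromatic carbon keeps the number in the range of bromo, with a 1.8-fold lower number from compound 2 to compound 3 (0.25 log units; within the scatter), so this position accepts a group with a triple bond. Against trifluoromethyl the change gives a 2.3-fold lower number from compound 1 to compound 3 (0.36 log units; beyond the scatter), the first step at this position to pass beyond the scatter, though only modestly. No measurement at hand gives a reason for either step. Still open, from the compounds shown here alone, is whether an amine, a carboxylic acid or a methoxy group on this carbon would stay in this range. Also open, going by these compounds, is whether cyano would fare alike elsewhere on the ring.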